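Aryl ether variation at the oxygen, cytotoxicity on MRC5 cells

The source may hold more compounds than are shown below. What is called first, only, known or untested is meant among the compounds shown, and "the series" means these compounds.

Notes on the series. Compound 1 `Cc1cn(C2CCN(Cc3cccc(Oc4ccc(Cl)cc4)c3)CC2)c(=O)[nH]c1=O` gives 25100 nM in an ADME assay on MRC5 cells (Homo sapiens) for cytotoxicity, read by fluorescence and resazurin assay, with a stated time of 3 days; a higher number here means a weaker inhibitor, a lower number a stronger inhibitor. For the measured compounds named here, compound 2 `Cc1cn(C2CCN(Cc3cccc(Oc4cccc(OC(F)(F)F)c4)c3)CC2)c(=O)[nH]c1=O` gives 5260 nM in this assay, and the one-place step a 4.8-fold lower number from compound 1 to compound 2 (0.68 log units; beyond the scatter) is the only step measured so far, lying at the same position as the change now considered. Compound 3 `Cc1cn(C2CCN(Cc3cccc(Oc4ccncc4)c3)CC2)c(=O)[nH]c1=O` gives "not determined" (no result reported) in this assay, so compound 3 stands unplaced among the measured compounds. Compound 4 `Cc1cn(C2CCN(Cc3cccc(Oc4cccc(F)c4)c3)CC2)c(=O)[nH]c1=O` differs from compound 3 by 3-fluorophenyl in place of pyridin-4-yl on an oxygen on an aromatic ring. Going by the values given here, with no number for compound 3, no step can be sized from it; the two measured aryl ethers, compound 1 and compound 2, bound the region where compound 4 is expected to fall. For compound 4 the value in this assay is estimated at 12000 nM, within 3000 nM to 45000 nM.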

Compound 4, half-maximal inhibitory concentration: > 64000 nM
Compound 4: only a limit was reported; the forecaster's own chance of this, stated with the estimate: 20%; middle value at least 5.3-fold (0.72 log units) from the limit.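

The reading for compound 4 is a limit, not a number: the limit of > 64000 nM in this assay, at which 1 of the 4 values shown sits. At the oxygen-linked aryl ring, the small swap of fluoro in place of trifluoromethoxy gives an at least 12-fold higher number from compound 2 to compound 4 (1.08 log units; beyond the scatter) in this assay. With 3-fluorophenyl in place of 4-chlorophenyl there is an at least 2.5-fold higher number from compound 1 to compound 4 (0.40 log units; beyond the scatter), so compound 2 now gives the lowest number of the three measured aryl ethers.

Steps from compound 3 cannot be read, and the true size of both new steps stays open. Also open, from the compounds shown here alone, is how an amine or a carboxylic acid on this aryl ring would read in this assay.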